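Cyclopentyl Ketone in Place of a Trifluoromethyl Ketone

The compounds below may be only part of what the source reports. "The series", "measured", "known", "first", "only" and "open" are said of these compounds alone.

Of the compounds shown here, three sharing one core have been measured in a functional assay on isolated protein for inhibition of Glucose-dependent insulinotropic receptor (Rattus norvegicus), read by HTRF and cAMP accumulation; on this read-out lower numbers stand for smaller maximal responses and higher numbers for larger maximal responses. Compound 1 `Cc1nc(S(C)(=O)=O)ccc1Oc1ncnc(OC2CCN(C(=O)OC3CCC3)CC2)c1F` gives 81% in this assay, compound 2 `Cc1nc(S(C)(=O)=O)ccc1Oc1ncnc(OC2CCN(C(=O)O[C@H](C)C(F)(F)F)CC2)c1F` gives 85%, and compound 3 `Cc1nc(S(C)(=O)=O)ccc1Oc1ncnc(OC2CCN(C(=O)C(F)(F)F)CC2)c1F` gives 76%. Compound 3 thus holds the smallest of the three numbers, yet neither gap reaches beyond the scatter: a number 5 percentage points lower from compound 1 to compound 3 (within the scatter), and a number 9 percentage points lower from compound 2 to compound 3 (within the scatter). Likewise a number 4 percentage points higher from compound 1 to compound 2 (within the scatter).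

Compound 4 `Cc1nc(S(C)(=O)=O)ccc1Oc1ncnc(OC2CCN(C(=O)C3CCCC3)CC2)c1F` differs from compound 3 in one place: cyclopentyl in place of trifluoromethyl on a carbonyl carbon. The two steps that bear on this change are those ending at compound 3, in which a cyclobutyloxy or a 1-(trifluoromethyl)ethoxy group on the carbonyl carbon was exchanged for trifluoromethyl, and both moved the maximal response only within the scatter. Replacing the trifluoromethyl by cyclopentyl on the same carbonyl carbon is therefore expected to give no step beyond the scatter in this assay, with at most a slight drift back toward the numbers of compound 1 and compound 2, so that a number 5 percentage points higher from compound 3 to compound 4 (within the scatter) is the expected outcome. For compound 4 the estimate in this assay is 81%, expected to fall between 70% and 92%.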

Compound 4, largest response reached (reported as efficacy), in percent of the reference or control that the assay uses: 83%
Compound 4: the middle estimate sits 2 percentage points below what was measured; the range from low to high includes it.
By their numbers in this assay, from the lowest: compounds 3, 1, 4 and 2 (each within the scatter of the next).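

In this assay, a carbonyl carbon whose other neighbour is the amide-type nitrogen in a ring now carries cyclopentyl, a group with no fluorine and no oxygen, and the exchange for trifluoromethyl stays within the scatter: a number 7 percentage points higher from compound 3 to compound 4 (within the scatter). The exchanges for the two oxygen-linked groups on the same carbon also stay within it, with a number 2 percentage points higher from compound 1 to compound 4 (within the scatter) and a number 2 percentage points lower from compound 2 to compound 4 (within the scatter), so among these four compounds, neither fluorine nor an oxygen in this group is needed for a maximal response in this range, which the earlier compounds could not show because each of them carried one or the other. Nothing at hand offers an explanation for this flat picture at the position.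

The four compounds leave open whether any group on this carbonyl carbon can carry the maximal response beyond the scatter, since all of them lie within it. Whether a dimethylamino group, a carboxylic acid on the cyclopentyl ring or a longer chain such as hexyl would fit the same picture remains an open question.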